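This account rests on a few compounds, and the source may have more. Where it says the series, first, only, none or still open, it means among the compounds named here.

Among the measured compounds shown here, in a functional assay on the whole organism for antagonist activity, with Mus musculus as the target (on this read-out higher numbers stand for an effect only at larger amounts of compound and lower numbers for an effect already at smaller amounts), compound 1 (`CCCCCC(=O)NCC(=O)N(C)c1ccc(Cl)cc1C(=O)c1ccccc1Cl`) gives 1.9 mg/kg and holds the lower of the two numbers so far, with a gap beyond the scatter to compound 2 (`NCC(=O)NCC(=O)Nc1ccc([N+](=O)[O-])cc1C(=O)c1ccccc1`), which gives 4.82 mg/kg in the same test. Compound 3 (`CCC(=O)NCC(=O)N(C)c1ccc(Cl)cc1C(=O)c1ccccc1Cl`) keeps the core of compound 1 and differs by hydrogen in place of propyl on a saturated chain carbon, two bonds along the chain from a carbonyl carbon with hydrogen in place of propyl on a saturated chain carbon, two bonds along the chain from a carbonyl carbon. For the measured compounds named here, no measured pair isolates this change. In this assay the expected step is a 1.5-fold higher number from compound 1 to compound 3 (0.17 log units; within the scatter) as a small rise in the number that stays within the scatter. For compound 3 the estimated value is 2.8 mg/kg with an expected range from 1 mg/kg to 8 mg/kg on this read-out.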

Compound 3, dose for half-maximal effect: 1.4 mg/kg
The estimate for compound 3 lay 2.0-fold (0.30 log units) above the measured number; the measured number falls inside the stated range.
By their numbers in this assay, from the lowest: compounds 3 and 1 (each within the scatter of the next); then compound 2.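

In this assay, among the compounds shown here, hydrogen in place of propyl on a saturated chain carbon, two bonds along the chain from a carbonyl carbon, gives a 1.4-fold lower number from compound 1 to compound 3 (0.13 log units; within the scatter), the first single-place comparison. At this place, the pentylcarbonyl and propanoyl chains are therefore not told apart by this read-out. Nothing on hand explains this result.

As far as these compounds go, whether a longer chain, a phenyl group or an amine at this place would stay within the same range remains open. So does whether the same change would read alike on the core of compound 2.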